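Swapping a Methyl for Hydrogen on the Aromatic Ring

The source may hold more compounds than are shown below. What is called first, only, known or untested is meant among the compounds shown, and "the series" means these compounds.

In a physicochemical assay for lipophilicity, read by HPLC, measured as chromatographic lipophilicity, at pH 7.4 (on this read-out higher numbers stand for higher lipophilicity and lower numbers for lower lipophilicity), compound 2 `Cc1ccc(C2CC=NN2C(=O)C(C)(C)C)cc1F` gives 6.6, while compound 1 `CC(C)(C)C(=O)N1N=CCC1c1cc(F)cc(F)c1` gives 6.3. These two values lie within the usual scatter of each other, and neither stands apart. Compound 3 `CC(C)(C)C(=O)N1N=CCC1c1cccc(F)c1` differs from compound 2 by a single change: hydrogen in place of methyl on an aromatic carbon. Within the data shown here, no measured pair of compounds shows this change directly. In this assay, a modest fall just beyond the scatter is expected, an estimated a number 0.50 log units lower from compound 2 to compound 3 (beyond the scatter). Compound 3 is estimated at 6.1, within an expected range from 5.7 to 6.5.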

Compound 3, distribution coefficient: 5.9
The estimate for compound 3 lay 0.20 log units above the measured number; measured number inside the range.
By their numbers in this assay, from the lowest: compound 3; then compounds 1 and 2 (each within the scatter of the next).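

Hydrogen in place of methyl on an aromatic carbon, para to a large group, gives a number 0.70 log units lower from compound 2 to compound 3 (beyond the scatter) in this assay, so a single carbon at this position produces a step that can be told apart from measurement noise. Hydrogen in place of fluoro on an aromatic carbon gives a number 0.40 log units lower from compound 1 to compound 3 (beyond the scatter), so among these compounds, the one with hydrogen in place of either group has the lowest number. Nothing measured here explains either fall. On these data alone, how an amine, a carboxylic acid or a longer chain at the methyl position would read remains open.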